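A few compounds are considered here, and "the series" means these few. Any claim that something is new, unique, unknown or untested is made for them only; others in the source may bear on it.

In a functional assay on U-251 cells (Homo sapiens) for inhibition, read by sulforhodamine B assay, with a stated time of 48 h (a higher number here means a weaker inhibitor of growth, a lower number a stronger inhibitor of growth), compound 1 `O=C(Cc1csc2nc(-c3ccc(Br)cc3)cn12)N/N=C/c1ccccc1O` gives 15100 nM and compound 2 `COc1cccc(OC)c1/C=N/NC(=O)Cc1csc2nc(-c3ccc(Br)cc3)cn12` gives 31600 nM, the higher number of the two. Compound 3 `O=C(Cc1csc2nc(-c3ccc(Br)cc3)cn12)N/N=C/c1ccc(Cl)cc1Cl` carries 2,4-dichlorophenyl in place of 2,6-dimethoxyphenyl on a carbon with a double bond to nitrogen. Within the data shown here, only one measured step bears on this place, a modest one that brought in 2,6-dimethoxyphenyl: a 2.1-fold higher number from compound 1 to compound 2 (0.32 log units; beyond the scatter). With that group gone, a similarly modest move back toward lower numbers is expected, though this single step is thin evidence. The estimated step is a 1.6-fold lower number from compound 2 to compound 3 (0.20 log units; within the scatter). For compound 3 the expected value is 20000 nM, with an estimated range of 8000 nM to 50000 nM.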

Compound 3, concentration for total growth inhibition: 44700 nM
The estimate for compound 3 lay 2.2-fold (0.35 log units) below the measured number; the measured number falls inside the stated range.
By their numbers in this assay, from the lowest: compound 1; then compounds 2 and 3 (each within the scatter of the next).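

In this assay, this place on a carbon with a double bond to nitrogen now has a second replacement: 2,4-dichlorophenyl in place of 2,6-dimethoxyphenyl gives a 1.4-fold higher number from compound 2 to compound 3 (0.15 log units; within the scatter), so the two groups are not separated here. In place of 2-hydroxyphenyl, the same group gives a 3.0-fold higher number from compound 1 to compound 3 (0.47 log units; beyond the scatter), which means that both replacements shown read weaker than 2-hydroxyphenyl, whether they bear chlorine or methoxy groups. Nothing available gives a cause for this. Still open, as far as these compounds go, is whether the hydroxyl group itself matters, and how a phenyl ring bearing an amine or a carboxylic acid would read.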